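The source may report more compounds than this note shows. Statements on the series, on what has been measured and on what is new or still open speak of the compounds shown alone.

In a functional assay on PC-3M cells (Homo sapiens) for cytotoxicity, read by MTT assay, with a stated time of 48 h (a higher number here means a weaker inhibitor, a lower number a stronger inhibitor), compound 1 `CCOC(=O)CSc1nnc(C)n1N1C(=O)c2ccccc2C1=O` returns only the assay limit, > 200000 nM.
Compound 2 `Cc1nnc(SCC(=O)c2ccc(Cl)cc2)n1N1C(=O)c2ccccc2C1=O` in this assay likewise returns a limit, > 200000 nM.
Compound 3 `Cc1nnc(SCC(=O)c2ccccc2)n1N1C(=O)c2ccccc2C1=O` in this assay also returns a limit, > 200000 nM.

Compound 2 therefore stands at the limit of > 200000 nM in this assay, at which 3 of the 3 values shown sit; no number separates it from the others. The three measured steps are all unreadable: a step that the two limits leave unreadable from compound 1 to compound 2, a step that the two limits leave unreadable from compound 1 to compound 3 and a step that the two limits leave unreadable from compound 2 to compound 3, so none gives a size or direction to carry forward.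

Compound 4 `COc1cc(-c2nnc(SCC(=O)c3ccc(Cl)cc3)n2N2C(=O)c3ccccc3C2=O)cc(OC)c1OC` differs from compound 2 by 3,4,5-trimethoxyphenyl in place of methyl on an aromatic carbon. Within the data shown here, no measured step bears readably on this change, so the expectation rests on the shared limit alone: the step from compound 2 is estimated as an at least 2.0-fold lower number from compound 2 to compound 4 (0.30 log units; that floor lies within the scatter). For compound 4 the estimate in this assay is 100000 nM, within 5000 nM to 400000 nM, with a real chance that only a limit is reported again.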

Compound 4, half-maximal inhibitory concentration: 20700 nM
Compound 4: middle estimate off by 4.8-fold (0.68 log units), on the high side; the measured number falls inside the stated range.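

Placing 3,4,5-trimethoxyphenyl in place of methyl on the aromatic carbon between two ring nitrogen atoms gives, in this assay, an at least 9.6-fold lower number from compound 2 to compound 4 (0.98 log units; beyond the scatter). Among these compounds, the steps among compounds 1, 2 and 3 cannot be read, so this carbon is the first place where a change gives a readable step, and that step is only a floor, since compound 2 is a limit. Compound 4 alone leaves the shared limit: the limit of > 200000 nM in this assay, at which 3 of the 4 values shown sit.

As far as these compounds go, it remains open whether an unsubstituted phenyl or an amine on this carbon would also leave the limit. From the compounds shown here alone, the same change with ethoxy or phenyl in place of 4-chlorophenyl on the carbonyl carbon is also open.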